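The source may hold more compounds than are shown below. What is called first, only, known or untested is meant among the compounds shown, and "the series" means these compounds.

Measured so far:
compound 1 `O=C1c2c[n+]([O-])c3ccccc3c2C(=O)c2c1c1ccccc1n2Cc1cn([C@H]2O[C@H](CO)[C@@H](O)[C@H]2O)nn1` — 2680 nM in a functional assay on A549 cells (Homo sapiens) for cytotoxicity, read by MTT assay, with a stated time of 72 h; on this read-out higher numbers stand for weaker inhibition and lower numbers for stronger inhibition
compound 2 `O=C1c2c[n+]([O-])c3ccccc3c2C(=O)c2c1c1ccccc1n2Cc1cn(C[C@H](O)CO)nn1` — 1030 nM
compound 3 `O=C1c2c[n+]([O-])c3ccccc3c2C(=O)c2c1c1ccccc1n2Cc1cn(CC(O)CO)nn1` — 880 nM

Compound 3 has the lowest of the three numbers: from compound 1 the step is a 3.0-fold lower number from compound 1 to compound 3 (0.48 log units; beyond the scatter), whereas compound 2 and compound 3 differ only in that (the fact that one of compounds 2 and 3 is drawn with a defined configuration and the other without, at the place where they differ), and the step of a 1.2-fold lower number from compound 2 to compound 3 (0.07 log units; within the scatter) is within the scatter.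

Compound 4 `O=C1c2c[n+]([O-])c3ccccc3c2C(=O)c2c1c1ccccc1n2CCCCN1CCNCC1`, not yet measured, changes compound 3 thus: 3-(piperazin-1-yl)propyl in place of 1-(2,3-dihydroxypropyl)-1H-1,2,3-triazol-4-yl on a saturated chain carbon bound to an aromatic nitrogen. For the measured compounds named here, no measured step covers a change of this kind; the steps of a 2.6-fold lower number from compound 1 to compound 2 (0.42 log units; beyond the scatter) and a 3.0-fold lower number from compound 1 to compound 3 (0.48 log units; beyond the scatter) both keep the ring that compound 4 loses and alter only the group on its aromatic nitrogen. No direction is expected beyond the scatter, and the range is wide. The estimate for compound 4 is 900 nM, from 250 nM to 3500 nM. That estimate corresponds to an expected step of a 1.0-fold higher number from compound 3 to compound 4 (0.01 log units; within the scatter).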

Compound 4, half-maximal inhibitory concentration: 540 nM
Estimate against measurement, compound 4: 1.7-fold (0.22 log units) above; measured number inside the range.
By their numbers in this assay, from the lowest: compounds 4, 3 and 2 (each within the scatter of the next); then compound 1.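

In this assay, this place accepts 3-(piperazin-1-yl)propyl in place of 1-(2,3-dihydroxypropyl)-1H-1,2,3-triazol-4-yl, since a 1.6-fold lower number from compound 3 to compound 4 (0.21 log units; within the scatter) and a 1.9-fold lower number from compound 2 to compound 4 (0.28 log units; within the scatter) both stay within the scatter. Among these compounds, neither the triazole ring nor the two hydroxyl groups are needed to keep cytotoxicity at this level. Nothing available accounts for this result.

Open, on these data alone, is whether chain length matters. A shorter or longer chain ending in piperazine, or the same chain ending in morpholine or a primary amine, would separate the effect of the chain from that of the terminal ring.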